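The source may hold more compounds than are shown below. What is called first, only, known or untested is meant among the compounds shown, and "the series" means these compounds.

Measured compounds:
compound 1 `CNC(=O)/C=C1\CCc2c(C)cc(F)cc21` gives 15% in a functional assay on the whole organism with Rattus norvegicus as the target, with a stated time of 3 h, at a dose of 20 mg/kg by the oral route; on this read-out higher numbers stand for more inhibition at the one dose given (going by the name of the read-out) and lower numbers for less inhibition
compound 2 `Cc1cc(F)cc2c1CC/C2=C\C(=O)NC1CC1` gives 5% in this assay

Among the compounds with values here, compound 2 holds the smaller of the two numbers in this assay; its only neighbour is compound 1, and the step of a number 10 percentage points lower from compound 1 to compound 2 (within the scatter) falls within the scatter, so the two compounds are not separated by this assay. Both numbers sit at the low end of the percentage scale.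

The next compound in the series is compound 3 `Cc1cc(F)cc2c1CC/C2=C\C(N)=O`. Relative to compound 2 the change is hydrogen in place of cyclopropyl on an amide-type nitrogen.

Within the data shown here, the one measured step that bears on this change is the exchange at the same amide-type nitrogen, cyclopropyl in place of methyl, a number 10 percentage points lower from compound 1 to compound 2 (within the scatter), which is within the scatter. Among the measured compounds shown here, with only that step available, the shift from cyclopropyl to hydrogen at the same place is not expected to move the number beyond the scatter in this assay, in either direction; the step of a number 5 percentage points higher from compound 2 to compound 3 (within the scatter) is the expected outcome. Compound 3 is therefore estimated at 10%, with a range from 0% to 25%, which also covers the numbers seen for compound 1 and compound 2.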

Compound 3, a percentage reported as inhibition, in the whole organism at one dose (the size of the read-out at that dose, not a potency): 11%
Beside the measured number, compound 3's estimate is 1 percentage points below it; low and high end bracket the measured number.
By their numbers in this assay, from the lowest: compounds 2, 3 and 1 (each within the scatter of the next).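

In this assay, taking the substituent off the amide-type nitrogen altogether does not separate the compounds: hydrogen in place of cyclopropyl gives a number 6 percentage points higher from compound 2 to compound 3 (within the scatter) and hydrogen in place of methyl gives a number 4 percentage points lower from compound 1 to compound 3 (within the scatter) as the second reading of the same change. With the earlier exchange of cyclopropyl for methyl, hydrogen, methyl and cyclopropyl at this nitrogen now form a set that this read-out does not tell apart, so neither a carbon group at this place nor a ring in that group shows up in the numbers for compound 1, compound 2 and compound 3. Nothing at hand gives a reason for this flat result.

On these data alone, all three numbers stay at the low end of the scale at the one dose given, so it remains open whether any group at this nitrogen can carry the number clear of the scatter, for instance a longer chain, an aminoethyl group or a hydroxyethyl group. Also open, as far as these compounds go, are a carboxylic acid in place of the amide and any change to the methyl or the fluorine on the shared core, read in this assay or at another dose.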